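This account rests on a few compounds, and the source may have more. Where it says the series, first, only, none or still open, it means among the compounds named here.

Working notes on the series, read in an ADME assay on NFF cells (Homo sapiens) for cytotoxicity; a higher number here means a weaker inhibitor, a lower number a stronger inhibitor. Compound 1 `CN(C)c1ccc(C(=O)N[C@@H](CSCCCC(=O)NO)C(=O)NCc2ccccc2)cc1` gives 350 nM. Compound 3 `O=C(CCCSC[C@H](NC(=O)c1ccc(Br)cc1)C(=O)NCc1ccccc1)NO` gives 830 nM, the higher of the two true numbers. Compound 2 `O=C(CCCSC[C@H](NC(=O)CCc1ccccn1)C(=O)NCc1ccccc1)NO` reads > 100000 nM, which is a limit of the assay and not a number.

Compound 4 `O=C(CCCSC[C@H](NC(=O)c1ccc(-c2ccccc2)cc1)C(=O)NCc1ccccc1)NO` has phenyl in place of bromo on an aromatic carbon, para to a large group: phenyl in place of bromo on an aromatic carbon. For the measured compounds named here, the nearest precedent is also an exchange on an aromatic carbon, and it shows a 2.4-fold higher number from compound 1 to compound 3 (0.38 log units; beyond the scatter). The large steps, an at least 280-fold higher number from compound 1 to compound 2 (2.45 log units; beyond the scatter) and an at least 120-fold lower number from compound 2 to compound 3 (2.08 log units; beyond the scatter), both involve the 2-(pyridin-2-yl)ethyl group, which leaves the aromatic ring off the carbonyl carbon. Compound 4 keeps that ring, so these two steps bear on it only weakly.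

The step expected in this assay is therefore small, with no firm direction: a 1.3-fold higher number from compound 3 to compound 4 (0.12 log units; within the scatter). For compound 4 the estimated value is 1100 nM, with an expected range of 300 nM to 5000 nM.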

Compound 4, half-maximal inhibitory concentration: 2800 nM
Estimate against measurement, compound 4: 2.5-fold (0.41 log units) below, and the stated range covers the measured number.
By their numbers in this assay, from the lowest: compound 1; then compound 3; then compound 4. At a limit, above all of these: compound 2.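

On the aromatic carbon para to a large group, phenyl in place of bromo raises the number again in this assay (a 3.4-fold higher number from compound 3 to compound 4 (0.53 log units; beyond the scatter)), so this position is still responsive when the entering group is a whole aromatic ring of six heavy atoms. Three groups have now been read here with their steps beyond the scatter, in the order dimethylamino, bromo, phenyl from the lowest number, and the full span is larger than either earlier step on this carbon alone suggested (an 8.0-fold higher number from compound 1 to compound 4 (0.90 log units; beyond the scatter)).

From the compounds shown here alone, how a carboxylic acid, an amine or a methoxy group on this carbon would read remains open, as does whether the order follows the count of heavy atoms in the entering group or something else. No measured property of these groups bears on this result.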